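Swapping the Sulfonamide Substituent in a Chromone-Free Series

This account rests on a few compounds, and the source may have more. Where it says the series, first, only, none or still open, it means among the compounds named here.

Compound 2, whose structure is `Cc1ccc(S(=O)(=O)N2CCN(C)CC2)cc1C#Cc1cc(Cl)ccc1OCC(=O)O`, holds the lower of the two numbers recorded in an assay on CHO cells for displacement of a labelled ligand from prostaglandin D2 receptor 2 (Homo sapiens), read by scintillation counting; on this read-out higher numbers stand for weaker inhibition and lower numbers for stronger inhibition. In this assay compound 2 gives 21 nM, while compound 1, structure `Cc1ncccc1C#Cc1cc(Cl)ccc1OCC(=O)O`, gives 143 nM, a difference that lies beyond the usual scatter. The untested compound 3, structure `Cc1ccc(S(=O)(=O)NC(C)C)cc1C#Cc1cc(Cl)ccc1OCC(=O)O`, is reached from compound 2 by one change: isopropylamino in place of 4-methylpiperazin-1-yl on a sulfonyl sulfur. Among the measured compounds shown here, no measured pair here shows the effect of such an exchange, so the direction of the step can only be guessed. The author expects the step from compound 2 to compound 3 to be modest, of a size a 1.7-fold higher number from compound 2 to compound 3 (0.22 log units; within the scatter), and probably towards a somewhat higher number, though it may also fall within the scatter. For compound 3 the estimated value in this assay is 35 nM, with a range from 12 nM to 100 nM.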

Compound 3, inhibition constant: 3.4 nM
Estimate against measurement, compound 3: 10-fold (1.01 log units) above; measured number below the stated range.
By their numbers in this assay, from the lowest: compound 3; then compound 2; then compound 1.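

Among the compounds shown here, exchanging 4-methylpiperazin-1-yl for isopropylamino on the sulfonyl sulfur gives a 6.2-fold lower number from compound 2 to compound 3 (0.79 log units; beyond the scatter) in this assay and is the first single change in this set that can be read. It shows that this place responds to the group on the sulfur, and that the six-membered ring is not needed for a low number: the smaller open group, which carries a hydrogen-bond donor where the ring carries none, does better here. No measurement shown accounts for the size or direction of this step.

A single pair cannot tell whether the ring's removal or the added hydrogen on the sulfonamide nitrogen matters more. Dimethylamino, which keeps the open form without that hydrogen, and cyclohexylamino, which keeps that hydrogen with a ring, would pull the two apart.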